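This account rests on a few compounds, and the source may have more. Where it says the series, first, only, none or still open, it means among the compounds named here.

Working notes on the series. Two compounds share the core of compound 1 `Nc1cccc2c(-c3cccc(NC(=O)c4ccc(C(F)(F)F)c(Cl)c4)c3)ccnc12` and have been measured in a functional assay on A375P cells (Homo sapiens) for antiproliferative activity, read by MTT assay, with a stated time of 48 h; a higher number here means a weaker inhibitor, a lower number a stronger inhibitor. Compound 1 gives 6100 nM in this assay, the lowest of the two numbers recorded. Compound 2 `Nc1cccc2c(-c3cccc(NC(=O)c4cc(Cl)cc(C(F)(F)F)c4)c3)ccnc12`, which carries its chloro and trifluoromethyl groups on different positions of the benzamide ring, gives 18500 nM in this assay, a higher number than compound 1 by a margin beyond the usual scatter. Among the measured compounds shown here, no pair among the measured compounds differs in one place only, so no single-point step is available to calibrate the change now under consideration.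

Compound 3 `CC(=O)Nc1cccc2c(-c3cccc(NC(=O)c4ccc(C(F)(F)F)c(Cl)c4)c3)ccnc12` keeps the whole of compound 1 except for one change: acetyl in place of hydrogen on a nitrogen on an aromatic ring. The measured compounds offer no precedent for capping this nitrogen, so the direction of the step rests on no shown data. A modest rise in the number is expected, with wide uncertainty, and the step from compound 1 to compound 3 is estimated as a 1.8-fold higher number from compound 1 to compound 3 (0.26 log units; within the scatter). Compound 3 is accordingly expected to give about 11000 nM in this assay, within a range from 3500 nM to 40000 nM.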

Compound 3, half-maximal inhibitory concentration: 7600 nM
The estimate for compound 3 lay 1.4-fold (0.16 log units) above the measured number, within the range that was stated.
By their numbers in this assay, from the lowest: compounds 1 and 3 (each within the scatter of the next); then compound 2.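

This position now has its first single-point step: acetyl in place of hydrogen on a nitrogen on an aromatic ring gives a 1.2-fold higher number from compound 1 to compound 3 (0.10 log units; within the scatter), so compound 1 and compound 3 cannot be told apart in this assay. At the level of activity seen in this pair, the number therefore does not depend on whether this nitrogen carries a free hydrogen, and the amino to acetamido exchange is accommodated on the shared core, although both compounds remain in the micromolar range. No measurement among the data shown bears on why the step is this small.

Going by these compounds, this reading rests on a single pair, so it remains open whether a longer acyl chain, a methanesulfonyl group or a dimethylamino group on this nitrogen would stay within the scatter of compound 1 or move beyond it. Among the compounds shown here, it also remains open whether the same acetyl step would hold with the arrangement of chloro and trifluoromethyl groups carried by compound 2, the one compound whose number stands apart from the others.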